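Pyridin-2-yl amide on the shared benzylidene thiazolidinedione core

The source may hold more compounds than are shown below. What is called first, only, known or untested is meant among the compounds shown, and "the series" means these compounds.

The series shares the core seen in compound 1 `Cc1cnc(NC(=O)COc2ccc(/C=C3\SC(=O)NC3=O)cc2)s1`, a thiazolidinedione joined through an aryloxyacetamide to a heteroaryl amine. In a functional assay on HepG2 cells (Homo sapiens) for cytotoxicity, read by sulforhodamine B assay, with a stated time of 48 h (on this read-out higher numbers stand for weaker inhibition of growth and lower numbers for stronger inhibition of growth), compound 1 gives < 100000 nM, which is a limit of the assay and not a number. Compound 2 `CCCCC1=NC2(CCCC2)C(=O)N1C(=O)COc1ccc(/C=C2/SC(=O)NC2=O)cc1` carries a spiro-fused imidazolinone on the amide nitrogen; in this assay compound 2 gives < 100000 nM, again a limit. Compound 3 `O=C1NC(=O)/C(=C\c2ccc(OCC(=O)N3C(=O)c4ccccc4S3(=O)=O)cc2)S1` bears a cyclic sulfonyl imide on that nitrogen; in this assay compound 3 gives < 100000 nM, also a limit. So far, then, every measured member sits at the same limit: the limit of < 100000 nM in this assay, at which 3 of the 3 values shown sit. For the measured compounds named here, no step between two measured compounds can be drawn from this, and compound 1 cannot be placed above or below either of its companions.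

Compound 4 `O=C(COc1ccc(/C=C2\SC(=O)NC2=O)cc1)Nc1ccccn1` is the next member. It differs from compound 1 by pyridin-2-yl in place of 5-methyl-1,3-thiazol-2-yl on an amide-type nitrogen. With all three known values resting at a limit, no direction can be read from the set, and no step beyond the scatter is expected; the most likely outcome is a fourth limit.

Compound 4 is expected to give about 40000 nM in this assay, within 5000 nM to 150000 nM, a step that the limit leaves unreadable from compound 1 to compound 4 that is an estimate rather than a measurement.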

Compound 4, concentration for 50% growth inhibition: < 100000 nM
Compound 4: only a limit was reported (the forecaster's own chance of this, stated with the estimate: 70%); the middle value does not contradict the limit.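

No step can be read from compound 1 to compound 4: in this assay both results are limits and not numbers, so the effect of pyridin-2-yl in place of 5-methyl-1,3-thiazol-2-yl on the amide-type nitrogen stays unreadable. The compounds shown leave open how any member ranks against another, because all results rest at one value: the limit of < 100000 nM in this assay, at which 4 of the 4 values shown sit.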